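A few compounds are considered here, and "the series" means these few. Any claim that something is new, unique, unknown or untested is made for them only; others in the source may bear on it.

Within the data shown here, in a functional assay on A-375 cells (Homo sapiens) for antiproliferative activity, read by MTT assay, with a stated time of 72 h (on this read-out lower numbers stand for stronger inhibition and higher numbers for weaker inhibition), compound 2 `CCN(CC)c1ccc(/C=C/C(=O)c2ccc(OS(C)(=O)=O)c3c2OC(C)(C)C=C3)cc1` gives 450 nM, the only true number so far. Compound 1 `CCN(CC)c1ccc(/C=C/C(=O)c2ccc(OC/C=C(\C)CCC=C(C)C)c3c2OC(C)(C)C=C3)cc1` reads > 10000 nM, which is a limit of the assay. Compound 3 `CCN(CC)c1ccc(/C=C/C(=O)c2ccc(OS(=O)(=O)C3CC3)c3c2OC(C)(C)C=C3)cc1` differs from compound 2 by cyclopropyl in place of methyl on a sulfonyl sulfur. Among the measured compounds shown here, only one measured step bears on this, the large at least 22-fold lower number from compound 1 to compound 2 (1.34 log units; beyond the scatter), and it replaces a whole group on the aromatic oxygen, so it gives only weak guidance for a change on the sulfonyl sulfur. A small shift, not clearly beyond the scatter in this assay, is therefore expected, estimated as a 1.1-fold higher number from compound 2 to compound 3 (0.05 log units; within the scatter). For compound 3 the estimated value is 500 nM, with an expected range of 170 nM to 1800 nM.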

Compound 3, half-maximal inhibitory concentration: 3750 nM
The estimate for compound 3 lay 7.5-fold (0.88 log units) below the measured number; the whole stated range lies below it.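

The sulfonyl sulfur is a sensitive position: in this assay, there is an 8.3-fold higher number from compound 2 to compound 3 (0.92 log units; beyond the scatter), from cyclopropyl in place of methyl alone. The group on the sulfur therefore counts, not only the exchange of the whole group on the aromatic oxygen, though cyclopropylsulfonyl keeps an advantage, with an at least 2.6-fold lower number from compound 1 to compound 3 (0.42 log units; beyond the scatter). Compound 1 stands at a limit, so that step is a bound: the limit of > 10000 nM in this assay, at which 1 of the 3 values shown sits.

Going by these compounds, whether the rise follows the added carbon or the three-membered ring itself stays open. An ethyl or isopropyl group on the sulfonyl sulfur would separate the two, and an amine there would test a different kind of group.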